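Extending one side chain of compound 1

The source may hold more compounds than are shown below. What is called first, only, known or untested is meant among the compounds shown, and "the series" means these compounds.

Within the data shown here, in a functional assay on HeLa cells (Homo sapiens) for inhibition (on this read-out lower numbers stand for stronger inhibition and higher numbers for weaker inhibition), compound 1 `CC(C)=CCC/C(C)=C/C[C@]12C(=O)CC(=O)[C@](CC=C(C)C)(C[C@@H](CC=C(C)C)C1(C)C)C2=O` gives 11.7 ug/mL, the only true number available so far. Compound 2 `CC(C)=CCC/C(C)=C/C[C@]12C[C@@H](CC=C(C)C)C(C)(C)[C@](C/C=C(\C)CCC=C(C)C)(C(=O)C(C(=O)c3ccc(O)c(O)c3)=C1O)C2=O` is reported only as a limit, > 20 ug/mL. Compound 3 `CC(C)=CCC/C(C)=C/C[C@]12C[C@@H](CC=C(C)C)C(C)(C)[C@](C/C=C(\C)CCC=C(C)C)(C(=O)CC1=O)C2=O` keeps the core of compound 1 and differs in a single side chain, where 3-methylbut-2-en-1-yl grows into 3,7-dimethylocta-2,6-dien-1-yl. Counted as a difference, this is 3-methylbut-2-en-1-yl in place of hydrogen on a saturated chain carbon bound to a double-bonded chain carbon: 3-methylbut-2-en-1-yl stands in place of hydrogen on a saturated chain carbon bound to a double-bonded chain carbon. Among the measured compounds shown here, no measured pair shows what this change does in this assay, so compound 1 at 11.7 ug/mL is the only anchor. The expected change a 1.1-fold higher number from compound 1 to compound 3 (0.05 log units; within the scatter) is small, within the usual scatter, with no clear direction. Compound 3 is estimated at 13 ug/mL, with an expected range from 6 ug/mL to 26 ug/mL.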

Compound 3, half-maximal inhibitory concentration: > 20 ug/mL
Compound 3 gave a limit, no number; the forecaster's own chance of this, stated with the estimate: 20%; middle value at least 1.5-fold (0.18 log units) from the limit.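

Compound 3 is reported in this assay only as a limit (> 20 ug/mL). Among these compounds, this gives the first reading of what happens when 3-methylbut-2-en-1-yl grows into 3,7-dimethylocta-2,6-dien-1-yl on a saturated chain carbon bound to a double-bonded chain carbon, and the longer chain brings no gain in inhibition, with a step of an at least 1.7-fold higher number from compound 1 to compound 3 (0.23 log units; that floor lies within the scatter). That step is only a floor, so it does not establish a real loss and the true size could be larger, because the reading for compound 3 ends at a limit: the limit of > 20 ug/mL in this assay, at which 2 of the 3 values shown sit.

Compound 2 and compound 3 both end at a limit, so the step between them cannot be read. Going by these compounds, whether a shorter chain such as ethyl, or a chain ending in an amine or a carboxylic acid, would change inhibition at this place remains open.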